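The compounds below may be only part of what the source reports. "The series", "measured", "known", "first", "only" and "open" are said of these compounds alone.

Measured so far in a physicochemical assay for lipophilicity, read by HPLC; a higher number here means a more lipophilic compound, a lower number a more polar compound:
- compound 1 `Cc1ccsc1C(=CCCN(C)C(CCO)C(=O)NCc1ccc(F)cc1F)c1sccc1C`: 6.37
- compound 2 `Cc1ccsc1C(=CCCN(C)C(CC(C)O)C(=O)NCc1ccc(Cl)cc1)c1sccc1C`: 5.99; 6.77 (2 entries)

In this assay compound 1 has one single number, 6.37, and one further entry that gives no single number. This number falls inside the span of the entries for compound 2, and that span is wide: the several entries of compound 2 in this assay, 5.99; 6.77 (2 entries).

Compound 3 `Cc1ccsc1C(=CCCN(C)C(CCO)C(=O)NCc1ccccc1Cl)c1sccc1C` has no reading yet. Its difference from compound 1 is 2-chlorophenyl in place of 2,4-difluorophenyl on a saturated chain carbon bound to an amide-type nitrogen. Cut one bond further out, the same change reads 2,4-difluorobenzyl to 2-chlorobenzyl.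

Going by the values given here, no pair of measured compounds differs in one place, so the size of this step cannot be read from data. A small upward step in this assay, not beyond the scatter, is expected: a number 0.13 log units higher from compound 1 to compound 3 (within the scatter). The estimated range is kept wide on the evidence of compound 2, with its entries 5.99; 6.77 (2 entries). For compound 3 the expected value is 6.5, with an estimated range from 6 to 7.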

Compound 3, partition coefficient: 6.23
The estimate for compound 3 lay 0.27 log units above the measured number; the range from low to high includes it.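

In this assay, going by these compounds alone, placing 2-chlorophenyl where compound 1 has 2,4-difluorophenyl, on a saturated chain carbon bound to an amide-type nitrogen, gives the first step that can be read: a number 0.14 log units lower from compound 1 to compound 3 (within the scatter). Within the data shown here, at this position, then, exchanging two ring fluorines for one ring chlorine leaves the reading within the scatter, a result the earlier compounds could not show, as no measured pair differed in one place. The direction of this step carries no weight, and its size is small beside the spread of repeated entries for a single compound in this series: the several entries of compound 2 in this assay, 5.99; 6.77 (2 entries)

Among these compounds, compound 2 differs from compound 1 and compound 3 in more than one place, so no step to it can be read, and the chain bearing the hydroxyl group remains untested as a single change. Also open, from the compounds shown here alone, is whether this single comparison extends to other halogen patterns, or whether a more different group at the same place, such as a pyridine ring, an amine or a carboxylic acid on the phenyl ring, would move the reading beyond the scatter.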